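Chlorine for fluorine at the benzyl ether position

The source may report more compounds than this note shows. Statements on the series, on what has been measured and on what is new or still open speak of the compounds shown alone.

Measured compounds in a functional assay on HEK293 cells for agonist activity at G-protein coupled receptor 39 (Homo sapiens), read by scintillation proximity assay and inositol phosphate accumulation, with a stated time of 75 min, in the presence of a further agent that is not named here; a higher number here means that more compound is needed for the effect, a lower number that less compound is needed:
Compound 1, `Cc1nn(-c2ncnc3nc[nH]c23)c2c1C(OCC(=O)c1ccc(F)cc1)CC(=O)N2`, gives 3 nM.
Compound 2, `Cc1nn(-c2ncnc3nc[nH]c23)c2c1C(OCc1ccccc1F)CC(=O)N2`, gives 4 nM.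
Compound 3, `Cc1nn(-c2ncnc3nc[nH]c23)c2c1C(C(=O)N(C)c1ccccc1)CC(=O)N2`, gives 32 nM.

Compound 1 has the lowest number of the three in this assay. Its nearest neighbour is compound 2, reached by a 1.3-fold higher number from compound 1 to compound 2 (0.12 log units; within the scatter), a change that stays within the scatter. Compound 3 lies furthest away, and the move to it is an 8.0-fold higher number from compound 2 to compound 3 (0.90 log units; beyond the scatter), beyond the scatter.

Compound 4, `Cc1nn(-c2ncnc3nc[nH]c23)c2c1C(OCc1ccccc1Cl)CC(=O)N2`, has not yet been measured. Its difference from compound 1 is 2-chlorophenyl in place of (4-fluorophenyl)carbonyl on a saturated chain carbon bound to an oxygen on a saturated carbon. Among the compounds with values here, the only measured step that bears on this is the step from compound 1 to compound 2, which swapped the same (4-fluorophenyl)carbonyl for 2-fluorophenyl at the same place and stayed within the scatter. The entering 2-chlorophenyl resembles that 2-fluorophenyl closely, so no step beyond the scatter is expected in this assay. Compound 4 is therefore estimated at 4 nM, with a range of 1.5 nM to 12 nM, which means an expected step of a 1.3-fold higher number from compound 1 to compound 4 (0.12 log units; within the scatter).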

Compound 4, half-maximal effective concentration: 2 nM
Compound 4: the middle estimate sits 2.0-fold (0.30 log units) above what was measured; the range from low to high includes it.
By their numbers in this assay, from the lowest: compounds 4, 1 and 2 (each within the scatter of the next); then compound 3.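

In this assay, chloro in place of fluoro on an aromatic carbon leaves the result unresolved, with a 2.0-fold lower number from compound 2 to compound 4 (0.30 log units; within the scatter), so the two halogens cannot be told apart at this position. The 2-chlorobenzyl group likewise stays level with the ((4-fluorophenyl)carbonyl)methyl group, with a 1.5-fold lower number from compound 1 to compound 4 (0.18 log units; within the scatter), so a second ether without the carbonyl now matches compound 1. The methyl(phenyl)carbamoyl group on the saturated ring carbon stands apart from this ether as well, with a 16-fold lower number from compound 3 to compound 4 (1.20 log units; beyond the scatter), which gives a second halogen-bearing benzyl ether clearly separated from compound 3.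

Nothing available explains why these ethers stay level or why compound 3 stands apart. Going by these compounds, it also remains open whether bromo, methoxy, trifluoromethyl, an amine or a carboxylic acid on the benzyl ring would keep the number in this range.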